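Removing the isopropoxy side chain from compound 2

The source may report more compounds than this note shows. Statements on the series, on what has been measured and on what is new or still open speak of the compounds shown alone.

Of the compounds shown here, three sharing one core have been tested in a functional assay on MCF7 cells (Homo sapiens) for antiproliferative activity; a lower number here means a stronger inhibitor, a higher number a weaker inhibitor. Compound 1 `COc1cc(Cc2nc3c(N)nc(F)nc3n2CCOC(C)C)cc(OC)c1OC` gives 15800 nM, compound 2 `COc1cc(Cc2nc3c(N)ncnc3n2CCOC(C)C)cc(OC)c1OC` gives 38900 nM, and compound 3 `COc1cc(Cc2nc3c(N)nc(F)nc3n2CCOC(C)C)c(Cl)c(OC)c1OC` gives 5370 nM. Compound 2 holds the highest number of the three: the change a 2.5-fold higher number from compound 1 to compound 2 (0.39 log units; beyond the scatter) raised it, while the change a 2.9-fold lower number from compound 1 to compound 3 (0.47 log units; beyond the scatter) lowered it. Compound 4 `CCn1c(Cc2cc(OC)c(OC)c(OC)c2)nc2c(N)ncnc21` differs from compound 2 by hydrogen in place of isopropoxy on a saturated chain carbon, two bonds along the chain from an aromatic nitrogen. Neither measured step touches that chain, so nothing here speaks to the size or direction of this change, and compound 2 alone anchors the guess. Compound 4 is therefore expected to stay near its parent, a 1.3-fold higher number from compound 2 to compound 4 (0.11 log units; within the scatter), giving an estimated 50000 nM with a wide range from 15000 nM to 160000 nM.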

Compound 4, half-maximal inhibitory concentration: 79400 nM
Compound 4: the middle estimate sits 1.6-fold (0.20 log units) below what was measured; low and high end bracket the measured number.
By their numbers in this assay, from the lowest: compound 3; then compound 1; then compound 2; then compound 4.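

Replacing isopropoxy with hydrogen gives a 2.0-fold higher number from compound 2 to compound 4 (0.31 log units; beyond the scatter) in this assay, showing that this chain position affects the antiproliferative reading, with the shorter ethyl chain giving the weaker result of this pair. For the compounds shown here, the step is modest, and it is the only one here that changes this chain. No available evidence explains the shift.

The compounds shown leave open whether a methoxy, hydroxyl or dimethylamino group at this place would match isopropoxy. They also leave open whether the fluoro and chloro steps would carry over to the ethyl chain.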